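The source may report more compounds than this note shows. Statements on the series, on what has been measured and on what is new or still open speak of the compounds shown alone.

Measured so far in an ADME assay on TZM cells (Homo sapiens) for cytotoxicity; on this read-out lower numbers stand for higher toxicity in this test and higher numbers for lower toxicity in this test:
- compound 1 `COC(=O)c1cc(N)c(Nc2ccc(C#N)cc2)cc1Oc1c(C)cc(/C=C/C#N)cc1C`: > 22800 nM, a limit
- compound 2 `Cc1cc(/C=C/C#N)cc(C)c1Oc1cc(Nc2ccc(C#N)cc2)c(N)cc1C(=O)O`: 14900 nM

Within the data shown here, compound 2, at 14900 nM, holds the only actual number in this assay, so there is no numeric scale against which to rank it. The sole other result is the limit of compound 1.

Compound 3 `Cc1cc(/C=C/C#N)cc(C)c1Oc1cc(Nc2ccc(C#N)cc2)c(N)cc1C(N)=O` has amino in place of hydroxy on a carbonyl carbon, a carboxy to carbamoyl change: amino in place of hydroxy on a carbonyl carbon.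

Among the measured compounds shown here, only one measured step bears on this change, and it also alters what sits on that carbonyl carbon: an at least 1.5-fold lower number from compound 1 to compound 2 (0.18 log units; that floor lies within the scatter). That step is small, its floor lies within the scatter, and it involves a different replacement, so it offers only weak guidance. No step beyond the scatter is therefore expected in this assay, in either direction. A report of only a limit also remains possible for the next result.

Estimated, this is a 1.1-fold higher number from compound 2 to compound 3 (0.06 log units; within the scatter).

The expected value for compound 3 is 17000 nM, with an estimated range from 8000 nM to 36000 nM.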

Compound 3, half-maximal cytotoxic concentration: > 23600 nM
Compound 3: a limit, no number (the forecaster's own chance of this, stated with the estimate: 35%); at least 1.3-fold (0.14 log units) between middle value and limit.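

In this assay, the change from hydroxy to amino on the carbonyl carbon gives an at least 1.5-fold higher number from compound 2 to compound 3 (0.19 log units; that floor lies within the scatter). The floor of this step lies within the scatter, so the result does not separate the carbamoyl of compound 3 from the carboxy of compound 2, although the true step may be larger. Compounds 1 and 3 both end at limits, which leaves compound 2 as the only one of the methoxy, hydroxy and amino variants on this carbonyl carbon with a number, and the step between compounds 1 and 3 cannot be read: the limit of > 23600 nM in this assay, at which 1 of the 3 values shown sits.

On these data alone, how far the true value of compound 3 lies past its limit stays open, and with it whether the real step from compound 2 exceeds the scatter. Also open, as far as these compounds go, is how an N-methyl amide, an N,N-dimethyl amide or a tetrazole in place of the carboxy group would read in this assay, and whether any of them would give a number rather than a limit.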